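The compounds below may be only part of what the source reports. "The series", "measured", "known", "first", "only" and "open" are said of these compounds alone.

In a physicochemical assay for solubility, read by LC-MS, in phosphate buffer, with a stated time of 24 h, at pH 6.8 (on this read-out lower numbers stand for lower solubility and higher numbers for higher solubility), compound 3 (`C[C@@H](c1ccc(NC(=O)N2CC(c3ccc(N)nc3)C2)cc1)N1Cc2ccccc2C1=O`) gives 220000 nM. That is level with compound 1 (`C[C@@H](c1ccc(NC(=O)N2CC(c3cccnc3)C2)cc1)N1Cc2ccccc2C1=O`) at 130000 nM and short of compound 2 (`CCC(=O)N[C@@H](C)c1ccc(NC(=O)N2CC(c3cccnc3)C2)cc1`) at 700000 nM. Compound 4 (`C[C@H](NC(=O)c1ncccn1)c1ccc(NC(=O)N2CC(c3ccc(N)nc3)C2)cc1`) differs from compound 3 by a group of 9 heavy atoms (5 carbon, 3 nitrogen, 1 oxygen; one six-membered aromatic ring with 2 hetero atoms) in place of a group of 10 heavy atoms (8 carbon, 1 nitrogen, 1 oxygen; one five-membered non-aromatic ring with 1 hetero atom, one six-membered aromatic ring of carbon only), on a saturated chain carbon bound to an aromatic carbon and a saturated chain carbon; the entering group is ((pyrimidin-2-yl)carbonyl)amino. The closest measured change is a 5.4-fold higher number from compound 1 to compound 2 (0.73 log units; beyond the scatter), where the same group leaves, though the group entering there has no ring. The amino group, shared by compound 3 and compound 4, gave a 1.7-fold higher number from compound 1 to compound 3 (0.23 log units; within the scatter). No measured case has an aromatic ring in the entering group, so a somewhat smaller step is expected in this assay, estimated as a 2.7-fold higher number from compound 3 to compound 4 (0.44 log units; beyond the scatter). For compound 4 the estimate is 600000 nM, with an expected range of 250000 nM to 1400000 nM.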

Compound 4, solubility: 300000 nM
Compound 4: the middle estimate sits 2.0-fold (0.30 log units) above what was measured; the range from low to high includes it.
By their numbers in this assay, from the lowest: compounds 1, 3 and 4 (each within the scatter of the next, the first and the last beyond it); then compound 2.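

In this assay the step to ((pyrimidin-2-yl)carbonyl)amino on this saturated chain carbon reads as a 1.4-fold higher number from compound 3 to compound 4 (0.13 log units; within the scatter) and so shows no separation. An entering group with an aromatic ring thus reads level with the group it replaces, whereas the ringless group gave a 5.4-fold higher number from compound 1 to compound 2 (0.73 log units; beyond the scatter) on the core without the amino group. No measured property bears on this result.

Still open, going by these compounds, is how an amine or a carboxylic acid would read on this carbon. Also open, on these data alone, is whether the ringless group entering in compound 2 would give a similar step with the amino group present.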